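The source may hold more compounds than are shown below. What is called first, only, known or untested is meant among the compounds shown, and "the series" means these compounds.

Measured so far:
- compound 1, `CCCCCCCC/C=C\CCCCCCCC(=O)O[C@@H](C)COP(=O)(O)OC[C@H](N)C(=O)O`: "not active" (no number reported)
- compound 2, `CCCCCCCC/C=C\CCCCCCCC(=O)OC[C@@H](COCC)OP(=O)(O)OC[C@H](N)C(=O)O`: 12.3%

In an assay on HEK293 cells for agonist activity at probable G-protein coupled receptor 34 (Mus musculus), with a stated time of 1 h (a higher number here means a larger maximal response, a lower number a smaller maximal response), compound 1 is reported as "not active" (no number reported), with no number given. Within the data shown here, compound 2 gives 12.3% in this assay, the only number in this set, so it is the sole point of reference. Compound 3, `CCCCCCCC/C=C\CCCCCCCC(=O)OC[C@@H](COCc1ccccc1)OP(=O)(O)OC[C@H](N)C(=O)O`, differs from compound 2 in one place: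

phenyl in place of methyl on a saturated chain carbon bound to an oxygen on a saturated carbon

Among the measured compounds shown here, no step between measured compounds is known, so no measured change guides this one. Starting from the low response of compound 2, the expected step is a number 2.7 percentage points higher from compound 2 to compound 3 (within the scatter), small and possibly within the scatter. Compound 3 is therefore estimated at 15%, with a range from 0% to 35%.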

Compound 3, largest response reached (Emax), in percent of the reference or control that the assay uses: 9.6%
Beside the measured number, compound 3's estimate is 5.4 percentage points above it; the measured number falls inside the stated range.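

In this assay, phenyl in place of methyl on a saturated chain carbon bound to an oxygen on a saturated carbon gives a number 2.7 percentage points lower from compound 2 to compound 3 (within the scatter), so ethoxymethyl and (benzyloxy)methyl read alike here. This first measured step at this place shows that adding an aromatic ring leaves the maximal response as low as before. Nothing measured explains this result. As far as these compounds go, whether an amine, a carboxylic acid or a longer chain at this place would give a larger maximal response stays open.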